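The source may hold more compounds than are shown below. What is called first, only, known or untested is meant among the compounds shown, and "the series" means these compounds.

Among the compounds with values here, in a functional assay on MDA-MB-231 cells (Homo sapiens) for antiproliferative activity, read by MTT assay, with stated times of 72 h and 4 h (on this read-out lower numbers stand for stronger inhibition and higher numbers for weaker inhibition), compound 2 `O=C(Nc1ccc(Cl)c(-c2nnc3c(Cl)cccn23)c1)c1ccccc1` gives 58200 nM, the only number in this small set. Compound 1 `O=C(Nc1ccc(Cl)c(-c2nnc3c(Cl)cccn23)c1)c1ccc(C(F)(F)F)cc1F` reaches only the limit of this assay, > 100000 nM, so it gives no number at all. Compound 3 `O=C(Nc1ccc(Cl)c(-c2nnc3c(Cl)cccn23)c1)c1cccc(Cl)c1` differs from compound 2 by chloro in place of hydrogen on an aromatic carbon. Within the data shown here, no step between measured compounds exists here, so the size of the change can only be guessed: the expected shift of a 1.5-fold lower number from compound 2 to compound 3 (0.16 log units; within the scatter) lies within the usual scatter, with no clear direction. Compound 3 is therefore expected near 40000 nM, in a range from 10000 nM to 150000 nM.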

Compound 3, half-maximal inhibitory concentration: 66100 nM
Compound 3: the middle estimate sits 1.7-fold (0.22 log units) below what was measured, and the stated range covers the measured number.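

In this assay, the change of chloro in place of hydrogen gives a 1.1-fold higher number from compound 2 to compound 3 (0.06 log units; within the scatter). Within the data shown here, this is the first step in the set that can be read, and it shows that chloro on this aromatic carbon, meta to a large group, does not separate the two compounds. On these data alone, whether another group at this place, such as an amine, a carboxylic acid or a methoxy group, would move the number stays open. Compound 1 offers no number to compare, only a limit: the limit of > 100000 nM in this assay, at which 1 of the 3 values shown sits.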